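The source may hold more compounds than are shown below. What is called first, only, known or untested is meant among the compounds shown, and "the series" means these compounds.

Compound 1, `CCOC(=O)c1sc2ccc(NCc3c[nH]cn3)cc2c1NC(=O)c1ccccc1`, is the member of this small series that carries a plain phenyl on its amide carbonyl. In a functional assay on HeLa cells (Homo sapiens) for antiproliferative activity, read by MTT assay, with a stated time of 48 h (on this read-out lower numbers stand for stronger inhibition of growth and higher numbers for weaker inhibition of growth), compound 1 gives 17900 nM, the highest of the three numbers measured, although both of its neighbours lie within the scatter of it. Compound 2, `CCOC(=O)c1sc2ccc(NCc3c[nH]cn3)cc2c1NC(=O)c1ccc(C)cc1`, gives 11700 nM, and compound 3, `CCOC(=O)c1sc2ccc(NCc3c[nH]cn3)cc2c1NC(=O)c1ccc(C(F)(F)F)cc1`, gives 16800 nM. The steps between them are small: a 1.5-fold lower number from compound 1 to compound 2 (0.18 log units; within the scatter), a 1.1-fold lower number from compound 1 to compound 3 (0.03 log units; within the scatter), and a 1.4-fold higher number from compound 2 to compound 3 (0.16 log units; within the scatter). Compound 4, `CCOC(=O)c1sc2ccc(NCc3c[nH]cn3)cc2c1NC(=O)c1ccc(F)c(Cl)c1`, has not yet been measured; it differs from compound 1 by 3-chloro-4-fluorophenyl in place of phenyl on a carbonyl carbon. Among the measured compounds shown here, the two measured steps that alter the same phenyl, from compound 1 to compound 2 and from compound 1 to compound 3, both stayed within the scatter, so nothing among the measured compounds points to a step beyond the scatter in this assay for compound 4 either. Compound 4 is therefore expected to give about 15000 nM, between 6000 nM and 40000 nM, meaning an expected step of a 1.2-fold lower number from compound 1 to compound 4 (0.08 log units; within the scatter).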

Compound 4, concentration for 50% growth inhibition: 10700 nM
Compound 4: the middle estimate sits 1.4-fold (0.15 log units) above what was measured, within the range that was stated.
By their numbers in this assay, from the lowest: compounds 4, 2, 3 and 1 (each within the scatter of the next).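

Putting 3-chloro-4-fluorophenyl in place of phenyl on the carbonyl carbon adds two groups to that ring at once, yet in this assay this gives a 1.7-fold lower number from compound 1 to compound 4 (0.22 log units; within the scatter). The comparisons with the two singly changed rings read the same way, with a 1.6-fold lower number from compound 3 to compound 4 (0.20 log units; within the scatter) and a 1.1-fold lower number from compound 2 to compound 4 (0.04 log units; within the scatter), so no step among these four compounds leaves the scatter. Even with 8 heavy atoms entering for 6, this position shows no measurable sensitivity to the change in this assay. From the compounds shown here alone, whether an amine, a carboxylic acid or a longer chain in place of these aryl groups would give a step beyond the scatter remains open. No supporting data bear on why the numbers stay so close.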